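Adding one carbon to the hydroxy chain of compound 2

A few compounds are considered here, and "the series" means these few. Any claim that something is new, unique, unknown or untested is made for them only; others in the source may bear on it.

Within the data shown here, in an ADME assay on MT4 cells (Homo sapiens) for cytotoxicity, read by MTT assay, with a stated time of 5 days (a higher number here means that more compound is tolerated, a lower number that less compound is tolerated), compound 2 `COc1cc2cc(C#N)ccc2c(OC)c1Oc1cc(NCCCO)nc(Nc2ccc(C#N)cc2)n1` gives 23500 nM, the only true number so far. Compound 1 `COc1cc2cc(C#N)ccc2c(OC)c1Oc1cc(NCC2CCOCC2)nc(Nc2ccc(C#N)cc2)n1` gives only a limit, > 125000 nM.

Among the measured compounds shown here, the single measured step, an at least 5.3-fold lower number from compound 1 to compound 2 (0.72 log units; beyond the scatter), puts 2-hydroxyethyl in place of oxan-4-yl on the chain carbon bound to the nitrogen, and it lies beyond the scatter. For the measured compounds named here, it is the only measured evidence on how changing this chain shifts the number.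

Compound 3 `COc1cc2cc(C#N)ccc2c(OC)c1Oc1cc(NCCCCO)nc(Nc2ccc(C#N)cc2)n1` differs from compound 2 in one place: hydroxymethyl in place of hydroxy on a saturated chain carbon, three bonds along the chain from a nitrogen on an aromatic ring. Hydroxymethyl stands in place of hydroxy on a saturated chain carbon, three bonds along the chain from a nitrogen on an aromatic ring, so 3-hydroxypropyl becomes 4-hydroxybutyl. The chain still ends in hydroxy, whereas the measured step of an at least 5.3-fold lower number from compound 1 to compound 2 (0.72 log units; beyond the scatter) exchanged one whole group for another, so that step is only a loose guide to this smaller change.

No shift beyond the scatter is expected in either direction, and the estimated change is a 1.1-fold higher number from compound 2 to compound 3 (0.03 log units; within the scatter). For compound 3 the expected value is 25000 nM, with an estimated range of 10000 nM to 70000 nM.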

Compound 3, half-maximal cytotoxic concentration: 39100 nM
Compound 3: the middle estimate sits 1.6-fold (0.19 log units) below what was measured; measured number inside the range.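

Going from 3-hydroxypropyl to 4-hydroxybutyl gives a 1.7-fold higher number from compound 2 to compound 3 (0.22 log units; within the scatter), so in this assay this one change, on a saturated chain carbon, three bonds along the chain from a nitrogen on an aromatic ring, leaves the number unchanged within the scatter. Unlike the earlier step, which exchanged one whole group for another, this one keeps the hydroxy and alters only the length of the chain, and the new step from the oxan-4-yl chain, an at least 3.1-fold lower number from compound 1 to compound 3 (0.50 log units; beyond the scatter), lies beyond the scatter just as the earlier one does, so across these two hydroxy chains the gap to the oxan-4-yl chain remains. The value for compound 1 is a limit and not a number, so the true size of both steps that start from it stays unknown: the limit of > 125000 nM in this assay, at which 1 of the 3 values shown sits.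

The compounds shown leave open whether a longer chain than 4-hydroxybutyl, still ending in hydroxy, would also stay within the scatter of compound 3. They also leave open how the number would respond to an amine or a carboxylic acid in place of the hydroxy.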